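Chromone amides in a mast cell assay: one open step

The source may report more compounds than this note shows. Statements on the series, on what has been measured and on what is new or still open speak of the compounds shown alone.

The shared core of compound 1 `O=C(Nc1nccs1)c1cc(=O)c2ccccc2o1` carries an amide that joins it to a heterocycle. In a functional assay on cells (Mast cell, Rattus norvegicus) for inhibition, with a stated time of 15 min (on this read-out higher numbers stand for an effect only at larger amounts of compound and lower numbers for an effect already at smaller amounts), compound 1 gives > 18 ug/mL, and this is a limit of the measurement rather than a number. Compound 1 thus sits at the limit of > 18 ug/mL in this assay, at which 1 of the 2 values shown sits, with no firm value to anchor it. A second compound of the same core, compound 2 `CN(C(=O)c1cc(=O)c2ccccc2o1)c1ccccc1`, returned "nd(insoluble)" (no result reported) in this assay, so no value is available for it either. Among the measured compounds shown here, no step between two measured compounds exists in this set.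

Compound 3 `O=C(O)CCNC(=O)c1cc(=O)c2ccccc2o1` remains to be tested. Compared with compound 1 the change is 2-carboxyethyl in place of 1,3-thiazol-2-yl on an amide-type nitrogen. With compound 1 resting at a limit, the step from compound 1 to compound 3 in this assay is expected to be none beyond the scatter, as a step that the limit leaves unreadable from compound 1 to compound 3 describes, since nothing measured here points in either direction. Compound 3 is therefore estimated at 20 ug/mL in this assay, with a range from 8 ug/mL to 60 ug/mL, and a fair chance that only a limit is reported again.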

Compound 3, concentration for half-maximal effect: > 18 ug/mL
Compound 3: only a limit was reported (the forecaster's own chance of this, stated with the estimate: 60%); the middle value is on the limit's open side.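

Among the compounds shown here, compound 1 and compound 3 both end at a limit in this assay, so no step between them can be read: the limit of > 18 ug/mL in this assay, at which 2 of the 3 values shown sit. The compounds shown leave open whether any amide on the shared core gives a single number in this assay at all, and how the group on the amide-type nitrogen would then bear on it.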